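Swapping the Urea Aryl Group on Compound 1

This account rests on a few compounds, and the source may have more. Where it says the series, first, only, none or still open, it means among the compounds named here.

Values in a functional assay on RS4-11 cells (Homo sapiens) for inhibition, read by CCK-8 assay, with a stated time of 48 h; a lower number here means a stronger inhibitor, a higher number a weaker inhibitor:
- Compound 1 `COc1ccc(NC(=O)NCCNS(=O)(=O)c2sccc2-c2ccc(C)cc2Oc2ccc(O)c(O)c2)cc1`: 8200 nM
- Compound 2 `COc1ccc(Oc2ccc([N+](=O)[O-])cc2-c2ccsc2S(=O)(=O)N2CCN(C(=S)Nc3ccc([N+](=O)[O-])cc3)CC2)cc1OC`: > 50000 nM (a limit of the assay, not a number)
- Compound 3 `COc1ccc(Oc2ccc(C(C)C)cc2-c2ccsc2S(=O)(=O)NCCNC(=O)Nc2cc(C(F)(F)F)cc(C(F)(F)F)c2)cc1OC`: 11700 nM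

Only two of these results are true numbers, and compound 1 lies within the usual scatter of compound 3. The limit for compound 2 gives no exact value to compare.

Compound 4 `Cc1ccc(-c2ccsc2S(=O)(=O)NCCNC(=O)Nc2cccc([N+](=O)[O-])c2)c(Oc2ccc(O)c(O)c2)c1` keeps the core of compound 1 and changes one group 3-nitrophenyl in place of 4-methoxyphenyl on an amide-type nitrogen: 3-nitrophenyl takes the place of 4-methoxyphenyl on an amide-type nitrogen. Within the data shown here, no measured pair differs in just this one place, so the expectation rests on thin evidence. Compound 3 has a different group on that nitrogen and differs elsewhere too, yet compound 3 gives 11700 nM, within the scatter of compound 1 at 8200 nM. No change beyond the scatter is therefore expected in this assay, in either direction. The expected change is a 1.1-fold higher number from compound 1 to compound 4 (0.04 log units; within the scatter). For compound 4, the estimated value is 9000 nM, with an expected range from 3000 nM to 30000 nM.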

Compound 4, half-maximal inhibitory concentration: 9100 nM
The estimate for compound 4 lay 1.0-fold (0.00 log units) below the measured number; the range from low to high includes it.
By their numbers in this assay, from the lowest: compounds 1, 4 and 3 (each within the scatter of the next). At a limit, above all of these: compound 2.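

Putting 3-nitrophenyl in place of 4-methoxyphenyl on an amide-type nitrogen gives a 1.1-fold higher number from compound 1 to compound 4 (0.05 log units; within the scatter) in this assay and this is the first pair shown that differs in this one place alone. On the core of compound 1, then, a methoxy-bearing ring and a nitro-bearing ring at this position cannot be told apart in this read-out, although the two groups differ in their atoms and in their hydrogen-bond acceptors. Nothing measured here explains why the number stays within the scatter.

On these data alone, whether any group at this position can move the number beyond the scatter remains open. As far as these compounds go, it is also open whether the aromatic ring is needed at all, which a cyclohexyl ring, a short alkyl chain or a phenyl ring bearing an amine or a carboxylic acid could test.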